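Formyl to cyano on the chain of compound 1

The source may report more compounds than this note shows. Statements on the series, on what has been measured and on what is new or still open speak of the compounds shown alone.

In a functional assay on HeLa cells (Homo sapiens) for inhibition (a higher number here means a weaker inhibitor, a lower number a stronger inhibitor), compound 1 (`Cc1cn(/C=C/C=O)c(=O)[nH]c1=O`) gives 23000 nM, at the low end of the three measured numbers. Compound 2 (`O=C/C=C/n1ccc(=O)[nH]c1=O`) gives 30000 nM, and compound 3 (`O=C/C=C/n1cc(F)c(=O)[nH]c1=O`) gives 60000 nM. The measured steps are all on an aromatic carbon: a 1.3-fold higher number from compound 1 to compound 2 (0.12 log units; within the scatter), a 2.6-fold higher number from compound 1 to compound 3 (0.42 log units; beyond the scatter) and a 2.0-fold higher number from compound 2 to compound 3 (0.30 log units; within the scatter). Compound 4 (`Cc1cn(/C=C/C#N)c(=O)[nH]c1=O`) has cyano in place of formyl on a double-bonded chain carbon bound to a double-bonded chain carbon. Among the compounds with values here, no measured step touches this group, so the data offer only the small spread of the series as a guide. In this assay the expected change is a 1.7-fold higher number from compound 1 to compound 4 (0.24 log units; within the scatter), so no step beyond the scatter is expected. Compound 4 is estimated at 40000 nM, with an expected range of 12000 nM to 130000 nM.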

Compound 4, half-maximal inhibitory concentration: > 100000 nM
Compound 4: only a limit was reported; the forecaster's own chance of this, stated with the estimate: 15%; at least 2.5-fold (0.39 log units) between middle value and limit.
By their numbers in this assay, from the lowest: compounds 1, 2 and 3 (each within the scatter of the next, the first and the last beyond it). At a limit, above all of these: compound 4.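

In this assay, within the data shown here, the earlier steps all sit on an aromatic carbon, and this is the first change on the chain: cyano in place of formyl gives an at least 4.3-fold higher number from compound 1 to compound 4 (0.63 log units; beyond the scatter). So the formyl at this place cannot be exchanged for cyano without a weaker inhibitor resulting. The reading for compound 4, > 100000 nM, is a limit, and the full size of the step stays open: the limit of > 100000 nM in this assay, at which 1 of the 4 values shown sits.

From the compounds shown here alone, whether a carboxylic acid or an ester at this place would keep the level of compound 1 remains open. So does whether cyano has the same effect with the hydrogen of compound 2 or the fluoro of compound 3.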